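The compounds below may be only part of what the source reports. "The series", "measured", "known", "first", "only" and "open" are said of these compounds alone.

Of the compounds shown here, two have been measured so far. Compound 1 `Cc1nc(S(C)(=O)=O)ccc1Oc1ncnc(OC2CCN(C(=O)OC3CCC3)CC2)c1F` and compound 2 `CCC1(OC(=O)N2CCC(Oc3ncnc(Oc4ccc(S(C)(=O)=O)nc4C)c3F)CC2)CC1` share the same core and differ only in the group on an oxygen next to a carbonyl group. In a functional assay on isolated protein for inhibition of Glucose-dependent insulinotropic receptor (Rattus norvegicus), read by HTRF and cAMP accumulation (a higher number here means a larger maximal response, a lower number a smaller maximal response), compound 1 gives 81%, and compound 2 gives 83%. The step of a number 2 percentage points higher from compound 1 to compound 2 (within the scatter) shows that exchanging one small ring for another at that place left the largest response unchanged within the usual scatter. Compound 2 stands at the higher of the two numbers, but its gap to compound 1 is too small to count as a difference.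

Compound 3 `CCC(F)(F)C(=O)N1CCC(Oc2ncnc(Oc3ccc(S(C)(=O)=O)nc3C)c2F)CC1` has not yet been measured. Relative to compound 2, the change is a group of 5 heavy atoms (3 carbon, 2 fluorine; no ring) in place of a group of 6 heavy atoms (5 carbon, 1 oxygen; one three-membered non-aromatic ring of carbon only), on a carbonyl carbon. For the measured compounds named here, the one measured step bears on this only loosely: it exchanged two ring-bearing groups on an oxygen, whereas here the ring and its oxygen leave altogether and a 1,1-difluoropropyl group enters on a carbonyl carbon. Going by the values given here, no measured step covers such a change. Since the step of a number 2 percentage points higher from compound 1 to compound 2 (within the scatter) barely moved the number, compound 3 is expected to reach a largest response near that of compound 2. The expected step is a number 5 percentage points lower from compound 2 to compound 3 (within the scatter), small and uncertain in direction. Compound 3 is therefore estimated at 78%, with a range from 64% to 92%.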

Compound 3, largest response reached (reported as efficacy), in percent of the reference or control that the assay uses: 90%
For compound 3 the middle estimate is 12 percentage points below the measured one, and the stated range covers the measured number.
By their numbers in this assay, from the lowest: compounds 1, 2 and 3 (each within the scatter of the next).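

In this assay, the change on the carbonyl carbon removes the ring and its oxygen together and brings in 1,1-difluoropropyl, and it gives a number 7 percentage points higher from compound 2 to compound 3 (within the scatter); set against the cyclobutyloxy group, the same group gives a number 9 percentage points higher from compound 1 to compound 3 (within the scatter). For the compounds shown here, the earlier pair showed only that one ring-bearing group on the oxygen could replace another, whereas these steps show that the largest response stays within the scatter even when neither the ring nor that oxygen remains at this carbonyl carbon, whose other neighbour is the amide-type nitrogen in a ring. Nothing available explains why the response holds up across this larger change.

The compounds shown leave open what the two fluorine atoms contribute, as a plain propyl group on the same carbonyl carbon would be needed to separate their part from that of the chain. They also leave open whether this tolerance extends to quite different groups at that place, such as an amine or a longer chain.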